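Dropping a Methoxy Group from a Pyrazole-Linked Enone

The source may report more compounds than this note shows. Statements on the series, on what has been measured and on what is new or still open speak of the compounds shown alone.

Measured in a functional assay on A549 cells (Homo sapiens) for cytotoxicity, read by sulforhodamine B assay, with a stated time of 48 h, tested at 0.1 uM; a higher number here means a weaker effect of the compound at the concentration tested, a lower number a stronger effect:
compound 1 `COc1cc(-c2cc(/C=C/C(=O)c3ccc(N)cc3)[nH]n2)cc(OC)c1OC` gives 94%
compound 2 `COc1ccc(-c2cc(/C=C/C(=O)c3ccc(OC)c(OC)c3)[nH]n2)cc1` gives 90%
compound 3 `COc1cc(-c2cc(/C=C/C(=O)c3ccc(Cl)c(Cl)c3)[nH]n2)cc(OC)c1OC` gives 99%

Among these three numbers compound 1 is neither the largest nor the smallest; its nearest neighbour is compound 2 and its furthest is compound 3, and both gaps lie within the scatter. Among the compounds with values here, the only measured single-point step, a number 5 percentage points higher from compound 1 to compound 3 (within the scatter), concerns the aryl ketone side of the shared core, not the ring where compound 4 `COc1ccc(-c2cc(/C=C/C(=O)c3ccc(N)cc3)[nH]n2)cc1OC` differs from compound 1: hydrogen in place of methoxy on an aromatic carbon. Within the data shown here, no measured step bears on this change, and all three numbers sit close together, so compound 4 is expected to show no step beyond the scatter in this assay, with a number 1 percentage points lower from compound 1 to compound 4 (within the scatter). Compound 4 is therefore estimated at 93%, between 80% and 102%.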

Compound 4, a percentage reported as activity, at one concentration (the size of the read-out at that concentration, not a potency): 93%
For compound 4 middle estimate and measured number coincide at the digits printed; the measured number falls inside the stated range.
By their numbers in this assay, from the lowest: compounds 2, 4, 1 and 3 (each within the scatter of the next).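

In this assay, within the data shown here, replacing methoxy with hydrogen gives a number 1 percentage points lower from compound 1 to compound 4 (within the scatter), the first reading at this place on the ring, as the earlier step concerned only the aryl ketone side. At this single concentration, then, this methoxy group can be lost without a change beyond the scatter. No available evidence explains this result. From the compounds shown here alone, it remains open whether a hydroxy group, a fluorine atom or a longer alkoxy chain at this position would move the number, and whether removing the methoxy group matters at other concentrations.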